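Benzimidazolyl substituent swap on the piperidine-linked core

The source may hold more compounds than are shown below. What is called first, only, known or untested is meant among the compounds shown, and "the series" means these compounds.

The series shares a core in which a piperidine carries a benzimidazol-derived group; compound 1 `CCCCn1c(=O)n(C2CCN(CC(O)Cn3nc(-c4ccc(Cl)c(C)c4)c4c3CCN(C(C)=O)C4)CC2)c2ccccc21`, compound 2 `CC(=O)N1CCc2c(c(-c3ccc(Cl)c(C)c3)nn2CC(O)CN2CCC(n3c(=O)n(C(C)C)c4ccccc43)CC2)C1` and compound 3 `CC(=O)N1CCc2c(c(-c3ccc(Br)cc3)nn2CC(O)CN2CCC(n3c(O)nc4ccc(Cl)cc43)CC2)C1` have been measured in an assay on isolated protein for inhibition of cathepsin S (Homo sapiens); on this read-out higher numbers stand for weaker inhibition and lower numbers for stronger inhibition. In this assay compound 1 gives 140 nM, compound 2 gives 100 nM and compound 3 gives 120 nM. Among the measured compounds shown here, the only single-point step measured so far is a 1.4-fold lower number from compound 1 to compound 2 (0.15 log units; within the scatter). Compound 3 stands second highest of the three numbers; its nearest neighbour is compound 1 and its furthest is compound 2, and neither gap exceeds the scatter of repeated measurements, so no order among the three can be claimed.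

Compound 4 `CC(=O)N1CCc2c(c(-c3ccc(Br)cc3)nn2CC(O)CN2CCC(n3c(O)nc4cccc(C)c43)CC2)C1` is not yet measured. It differs from compound 3 in one place: 2-hydroxy-7-methyl-1H-benzimidazol-1-yl in place of 6-chloro-2-hydroxy-1H-benzimidazol-1-yl on a saturated ring carbon. For the measured compounds named here, no measured step touches this part of the molecule; the step from compound 1 to compound 2 concerns the group on the aromatic nitrogen, not the substituent on the saturated ring carbon, and so it does not bear on the change at hand. Going by the values given here, with no relevant precedent, no step beyond the scatter is expected in either direction. The expected step is no change at the digits printed from compound 3 to compound 4 (within the scatter). Compound 4 is therefore estimated at 120 nM, with a range from 45 nM to 320 nM.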

Compound 4, half-maximal inhibitory concentration: 210 nM
Beside the measured number, compound 4's estimate is 1.8-fold (0.24 log units) below it; low and high end bracket the measured number.
By their numbers in this assay, from the lowest: compounds 2, 3, 1 and 4 (each within the scatter of the next, the first and the last beyond it).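

Among the compounds shown here, the first measured step at this position, 2-hydroxy-7-methyl-1H-benzimidazol-1-yl in place of 6-chloro-2-hydroxy-1H-benzimidazol-1-yl on a saturated ring carbon, reads in this assay as a 1.8-fold higher number from compound 3 to compound 4 (0.24 log units; within the scatter). This position therefore accepts a methyl-bearing group in place of a chlorine-bearing one without a step that can be told from the scatter, and the two groups match in heavy atoms, hydrogen-bond donors, hydrogen-bond acceptors and charge. Nothing on hand explains the size of this step.

The names of the two groups show that the substituent and its number on the ring change together, and no pair among the compounds shown separates these two changes. Also open, from the compounds shown here alone, are whether a carboxylic acid or an amine at this place on the ring would give a step beyond the scatter, and whether this reading carries over to the 4-bromophenyl-free compounds, which bear a chloro-methylphenyl group and a butyl or isopropyl group on an aromatic nitrogen.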